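Pyrimidinyl in Place of Methoxyphenyl on the Sulfonamide Nitrogen

The source may hold more compounds than are shown below. What is called first, only, known or untested is meant among the compounds shown, and "the series" means these compounds.

Compound 1 `COc1ccc(NS(=O)(=O)c2ccc(NC(=O)c3ccc(Cl)cc3Cl)cc2)cc1` was tested in a functional assay on HEK293 cells for agonist activity at probable G-protein coupled receptor 27 (Homo sapiens), read by a luciferase reporter and beta-arrestin recruitment, with a stated time of 10 min (a lower number here means that less compound is needed, a higher number that more compound is needed for the effect), and gives only a limit there, > 100000 nM, so its standing among the measured compounds cannot be fixed beyond that boundary, which is the limit of > 100000 nM in this assay, at which 1 of the 3 values shown sits. Compound 2 `Cc1cc(Cl)ccc1C(=O)Nc1ccc(S(=O)(=O)Nc2ccccc2)cc1` gives 912 nM in this assay, and compound 3 `O=C(Nc1ccc(S(=O)(=O)Nc2ccccc2)cc1)c1ccc(Br)cc1F` gives 479 nM. Among the compounds with values here, the one measured step, a 1.9-fold lower number from compound 2 to compound 3 (0.28 log units; within the scatter), alters the group on the carbonyl carbon and leaves the sulfonamide nitrogen untouched. Compound 4 `O=C(Nc1ccc(S(=O)(=O)Nc2ncccn2)cc1)c1ccc(Cl)cc1Cl` differs from compound 1 by pyrimidin-2-yl in place of 4-methoxyphenyl on a sulfonamide nitrogen, the amide part staying as in compound 1. Within the data shown here, no measured step touches the substituent on the sulfonamide nitrogen, so this change has no direct precedent among the measured compounds, and with compound 1 known only as a limit the size of the step cannot be computed from the data. Compound 4 is expected to give about 3000 nM, within a range from 400 nM to 50000 nM. The expectation is wide because compound 2 gives 912 nM and compound 3 gives 479 nM, showing the shared core can reach measurable numbers. The estimated step is an at least 33-fold lower number from compound 1 to compound 4 (1.52 log units; beyond the scatter).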

Compound 4, half-maximal effective concentration: > 100000 nM
Compound 4: no number, only a limit; the forecaster's own chance of this, stated with the estimate: 30%; middle value at least 33-fold (1.52 log units) from the limit.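

Compound 1 and compound 4 both stand only as limits in this assay, so no step between them can be read: the limit of > 100000 nM in this assay, at which 2 of the 4 values shown sit.

The compounds shown leave open whether pyrimidin-2-yl and 4-methoxyphenyl on the sulfonamide nitrogen differ at all, and how either behaves alongside the amide part of compound 2 or compound 3.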